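Shifting Fluorine on the Phenyl of a Histamine Agonist

The source may report more compounds than this note shows. Statements on the series, on what has been measured and on what is new or still open speak of the compounds shown alone.

Compound 1 `Cc1ccc(C(CC/N=C(\N)NCCCc2c[nH]cn2)c2ccccn2)cc1` gives 7.15 in a functional assay on muscle tissue for agonist activity at histamine H2 receptor (Cavia porcellus); a higher number here means a more potent compound, by a factor of ten per unit of this negative logarithm, a lower number a less potent compound. Compound 2 `N=C(NCCCc1c[nH]cn1)NCCC(c1ccc(F)cc1)c1ccccn1` gives 7.94 in this assay. Compound 3 `N=C(NCCCc1c[nH]cn1)NCCC(c1ccc(Cl)cc1)c1ccccn1` gives 7.39 in this assay.

Compound 3 stands second of the three: its value is close to that of compound 1, within the usual scatter, and it falls short of compound 2 by a step that lies beyond it. Going by the values given here, that one step, a number 0.55 log units lower from compound 2 to compound 3 (beyond the scatter), describes a chloro in place of fluoro on an aromatic carbon and is the only comparison available for this phenyl group.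

Compound 4 `N=C(NCCCc1c[nH]cn1)NCCC(c1cccc(F)c1)c1ccccn1` differs from compound 3 in one place: 3-fluorophenyl in place of 4-chlorophenyl on a saturated chain carbon bound to an aromatic carbon and a saturated chain carbon. This change does two things at once. Among the compounds with values here, it brings fluoro back in place of chloro, which in the one measured step went along with a modest gain. Within the data shown here, it also puts the fluoro on a different position of the ring, and no measured pair covers that shift, so its effect is unknown. On balance a modest rise from compound 3 is expected, smaller and less certain than a plain reversal of the measured step, with the expected step of a number 0.21 log units higher from compound 3 to compound 4 (within the scatter). Compound 4 is therefore estimated at 7.6 in this assay, within a range from 7.1 to 8.1.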

Compound 4, negative logarithm of the half-maximal effective concentration: 7.79
Compound 4: the middle estimate sits 0.19 log units below what was measured; low and high end bracket the measured number.
By their numbers in this assay, from the lowest: compounds 1 and 3 (each within the scatter of the next); then compounds 4 and 2 (each within the scatter of the next).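

In this assay, going by these compounds alone, the earlier compounds gave no view of where the fluoro sits on the phenyl ring, and 3-fluorophenyl in place of 4-fluorophenyl now shows as a number 0.15 log units lower from compound 2 to compound 4 (within the scatter), so these two fluoro compounds cannot be told apart. Within the data shown here, the swap of 4-chlorophenyl for 3-fluorophenyl, by contrast, shows as a number 0.40 log units higher from compound 3 to compound 4 (beyond the scatter), so both fluoro compounds stand clear of the one chloro compound, and within this small set the choice of fluoro or chloro matters more than which of these two fluorophenyl groups is present. No measurement shown here explains why fluoro and chloro part in this way.

Chloro appears only as 4-chlorophenyl, so a 3-chlorophenyl group would be needed to separate the effect of the atom from that of its place on the ring. From the compounds shown here alone, whether the tolerance seen for the two fluorophenyl groups extends to a 2-fluorophenyl group, a 3,4-difluorophenyl group or a plain phenyl group at this saturated chain carbon also stays open.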